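The source may hold more compounds than are shown below. What is called first, only, known or untested is meant among the compounds shown, and "the series" means these compounds.

Measured so far:
compound 1 `Cc1cc(C)c2sc(NC(=O)c3ccc([N+](=O)[O-])cc3)nc2c1`: 1.74 ug/mL
compound 2 `Cc1cc(C)c2sc(NC(=O)c3ccc(C(F)(F)F)cc3)nc2c1`: 1.36 ug/mL
compound 3 `COc1ccc2sc(NC(=O)c3ccc([N+](=O)[O-])cc3)nc2c1`: > 10 ug/mL, which is a limit of the assay and not a number

In a functional assay on SK-HEP1 cells (Homo sapiens) for antiproliferative activity, read by sulforhodamine B assay (a higher number here means a weaker inhibitor of growth, a lower number a stronger inhibitor of growth), compound 1 gives 1.74 ug/mL and compound 2 gives 1.36 ug/mL. The change between them is trifluoromethyl in place of nitro on an aromatic carbon; the step is a 1.3-fold lower number from compound 1 to compound 2 (0.11 log units; within the scatter). Compound 3 in this assay reaches only the limit > 10 ug/mL. The difference between the core of compound 1 and the core of compound 3 is not broken down here.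

Compound 4 `COc1ccc2sc(NC(=O)c3ccc(C(F)(F)F)cc3)nc2c1` is not yet measured. Its change from compound 3 is trifluoromethyl in place of nitro on an aromatic carbon, the same change as between compound 1 and compound 2, at the same place. Because a 1.3-fold lower number from compound 1 to compound 2 (0.11 log units; within the scatter) lies within the scatter, and compound 3 sits at the limit of > 10 ug/mL in this assay, at which 1 of the 3 values shown sits, the step is expected to be small, about a step that the limit leaves unreadable from compound 3 to compound 4, and compound 4 is expected to remain near the limit in this assay.

Compound 4 is estimated at 15 ug/mL, between 6 ug/mL and 40 ug/mL.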

Compound 4, concentration for 50% growth inhibition: > 10 ug/mL
Compound 4 gave a limit, no number; the forecaster's own chance of this, stated with the estimate: 70%; the middle value lies beyond the limit too.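

Compound 3 and compound 4 both stand at a limit of this assay, not at a number, so no step can be read between them: the limit of > 10 ug/mL in this assay, at which 2 of the 4 values shown sit.

From the compounds shown here alone, whether trifluoromethyl in place of nitro alters growth inhibition on the core of compound 3 stays open.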